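Testing a Chlorine-to-Hydrogen Swap on a Second Core

A few compounds are considered here, and "the series" means these few. Any claim that something is new, unique, unknown or untested is made for them only; others in the source may bear on it.

Compound 1 `Cc1nc(-c2ccc(Cl)cc2)sc1C(=O)CSc1nc(-c2ccccc2)c(C#N)c(=O)[nH]1`: 27600 nM
Compound 2 `Cc1nc(-c2ccccc2)sc1C(=O)CSc1nc(N)c(C#N)c(-c2ccc(Cl)cc2)n1`: 10800 nM
Compound 3 `Cc1nc(-c2ccccc2)sc1C(=O)CSc1nc(-c2ccccc2)c(C#N)c(=O)[nH]1`: 56600 nM

All three compounds were measured in a functional assay on U-87MG ATCC cells for antiproliferative activity against U-87 MG (Homo sapiens), read by MTT assay, with a stated time of 48 h; on this read-out lower numbers stand for stronger inhibition and higher numbers for weaker inhibition. Compound 1 and compound 3 share one core, while compound 2 is built on a different core; the difference between the two cores is not broken down here. Compound 1 and compound 3 differ in a single place: hydrogen in place of chloro on an aromatic carbon. In this assay that change produced a 2.1-fold higher number from compound 1 to compound 3 (0.31 log units; beyond the scatter). Among the three measured compounds, compound 2 gives the lowest number, and both of its gaps to the others lie beyond the scatter.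

Compound 4 `Cc1nc(-c2ccccc2)sc1C(=O)CSc1nc(N)c(C#N)c(-c2ccccc2)n1` has not yet been measured. It stands to compound 2 exactly as compound 3 stands to compound 1, the same change at the same kind of place: hydrogen in place of chloro on an aromatic carbon. Within the data shown here, the step is expected to resemble the earlier one, roughly a 2.1-fold higher number from compound 2 to compound 4 (0.33 log units; beyond the scatter), because a 2.1-fold higher number from compound 1 to compound 3 (0.31 log units; beyond the scatter) is the only guide available for this change, and it was made on a different core. Compound 4 is therefore estimated at about 23000 nM in this assay, expected to fall between 9000 nM and 60000 nM.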

Compound 4, half-maximal inhibitory concentration: 29000 nM
Beside the measured number, compound 4's estimate is 1.3-fold (0.10 log units) below it; low and high end bracket the measured number.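

In this assay, going from 4-chlorophenyl to phenyl gave a 2.7-fold higher number from compound 2 to compound 4 (0.43 log units; beyond the scatter), so losing the chloro raised the number on this second core as it did on the first. The size of the step also carried over, and the two cores give the same answer once ordinary assay noise is allowed for: the same change on two cores in this assay, a 2.1-fold higher number (0.31 log units; beyond the scatter) from compound 1 to compound 3 and a 2.7-fold higher number (0.43 log units; beyond the scatter) from compound 2 to compound 4, 1.3-fold (0.12 log units) apart, within the scatter of two such steps. This shows that, for these two pairs, the chloro-to-hydrogen change behaved alike on both cores, but two pairs in one cell assay cannot establish a general rule for the series, and they do not explain why the chloro lowers the number.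

The compounds shown compare only chloro and hydrogen at this spot, so it remains open whether a fluoro, bromo, methyl or methoxy group there would match the chloro or improve on it. As far as these compounds go, it is also open whether the same step would appear on a third core or in a different cell line.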